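Compound 3 to compound 4: replacing 4-pentylphenyl with tert-butyl

The source may hold more compounds than are shown below. What is called first, only, known or untested is meant among the compounds shown, and "the series" means these compounds.

Measured in a functional assay on A549 cells (Homo sapiens) for antiproliferative activity, read by MTT assay, with a stated time of 72 h; on this read-out lower numbers stand for stronger inhibition and higher numbers for weaker inhibition:
- compound 1 `O=C1O[C@H]([C@@H](O)Cn2cc(-c3cc(C(F)(F)F)cc(C(F)(F)F)c3)nn2)C(OCc2ccccc2)=C1OCc1ccccc1`: 28900 nM
- compound 2 `O=C1O/C(=C\Cn2cc(-c3cc(F)cc(F)c3)nn2)C(OCc2ccccc2)=C1OCc1ccccc1`: > 100000 nM
- compound 3 `CCCCCc1ccc(-c2cn(C[C@H](O)[C@H]3OC(=O)C(OCc4ccccc4)=C3OCc3ccccc3)nn2)cc1`: 6220 nM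

Compound 3 has the lower of the two true numbers, and compound 1 lies beyond the scatter from it. The entry for compound 2 is a limit of the assay and not a number.

Compound 4 `CC(C)(C)c1cn(C[C@H](O)[C@H]2OC(=O)C(OCc3ccccc3)=C2OCc2ccccc2)nn1` is unmeasured. It carries tert-butyl in place of 4-pentylphenyl on an aromatic carbon. Going by the values given here, no measured single-place step is available for comparison. The expectation rests on compound 3 at 6220 nM, whose 4-pentylphenyl is lost. In this assay, the expected step of a 6.4-fold higher number from compound 3 to compound 4 (0.81 log units; beyond the scatter) is towards a higher number, beyond the scatter. The estimate for compound 4 is 40000 nM, with an expected range of 15000 nM to 100000 nM.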

Compound 4, half-maximal inhibitory concentration: 34000 nM
Compound 4: the middle estimate sits 1.2-fold (0.07 log units) above what was measured, and the stated range covers the measured number.
By their numbers in this assay, from the lowest: compound 3; then compounds 1 and 4 (each within the scatter of the next). At a limit, above all of these: compound 2.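

In this assay, going by these compounds alone, this is the first single-place step: a 5.5-fold higher number from compound 3 to compound 4 (0.74 log units; beyond the scatter). With the shared core held, the group on the aromatic carbon of the five-membered ring therefore affects the read-out. Tert-butyl, with 4 heavy atoms and no ring, stands in place of 4-pentylphenyl, with 11 heavy atoms and a six-membered aromatic ring.

Nothing measured here gives a cause for this step. From the compounds shown here alone, the change removes ring and chain together, and how an unsubstituted phenyl or a straight hexyl chain would read at this position remains open.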